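Working notes: the step from compound 3 to compound 4

The source may hold more compounds than are shown below. What is called first, only, known or untested is meant among the compounds shown, and "the series" means these compounds.

Values in a functional assay on HCT-116 cells (Homo sapiens) for antiproliferative activity, read by MTT assay, with a stated time of 72 h (a higher number here means a weaker inhibitor, a lower number a stronger inhibitor), so far:
- compound 1 `CCCC(=O)NNC(=O)c1csc2ncc(-c3ccc(C)cc3)n12`: 34500 nM
- compound 2 `CCCC(=O)NNC(=O)c1csc2ncc(-c3ccc(OC)cc3)n12`: 59100 nM
- compound 3 `CC(=O)NNC(=O)c1csc2ncc(-c3ccc(Br)cc3)n12`: 6080 nM

Compound 3 has the lowest of the three numbers and stands beyond the scatter from both compound 1 and compound 2. Compound 4 `CCCC(=O)NNC(=O)c1csc2ncc(-c3ccc(Br)cc3)n12` follows from compound 3 by ethyl in place of hydrogen on a saturated chain carbon bound to a carbonyl carbon, which is ethyl in place of hydrogen on a saturated chain carbon bound to a carbonyl carbon, or acetyl to propylcarbonyl.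

Among the compounds with values here, the only measured step, a 1.7-fold higher number from compound 1 to compound 2 (0.23 log units; within the scatter), is methoxy in place of methyl on an aromatic carbon. Within the data shown here, it lies within the scatter and does not touch the chain, so no measured step isolates this change. Compound 1 (34500 nM) and compound 2 (59100 nM) already carry propylcarbonyl and show higher numbers than compound 3, but they also differ from it elsewhere. A modest move to a higher number in this assay is therefore expected, with low confidence. The expected size is an estimated 2.1-fold higher number from compound 3 to compound 4 (0.33 log units; beyond the scatter), at the edge of the scatter. Compound 4 is estimated at 13000 nM with an expected range (4500 nM to 38000 nM).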

Compound 4, half-maximal inhibitory concentration: 50300 nM
Compound 4: the middle estimate sits 3.9-fold (0.59 log units) below what was measured; measured number outside the range, above it.
By their numbers in this assay, from the lowest: compound 3; then compounds 1, 4 and 2 (each within the scatter of the next).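

In this assay the step of an 8.3-fold higher number from compound 3 to compound 4 (0.92 log units; beyond the scatter) shows that, with the bromo group held constant, this position responds to ethyl in place of hydrogen on a saturated chain carbon bound to a carbonyl carbon: going from acetyl to propylcarbonyl costs activity beyond the scatter. With propylcarbonyl held constant, the steps of a 1.2-fold lower number from compound 2 to compound 4 (0.07 log units; within the scatter) and a 1.5-fold higher number from compound 1 to compound 4 (0.16 log units; within the scatter) leave bromo, methoxy and methyl unseparated, so the low number of compound 3 is not a bromo effect seen across the propylcarbonyl compounds. No available evidence bears on the reason for the chain step.

Still open, from the compounds shown here alone, is whether acetyl gives a similar step when the aromatic carbon carries methyl or methoxy instead of bromo. Also open, going by these compounds, is how propionyl, or a longer chain ending in an amine, would read at this position.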